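The source may hold more compounds than are shown below. What is called first, only, known or untested is meant among the compounds shown, and "the series" means these compounds.

Compounds measured so far:
compound 1, `COc1cc(NC(C)CCCNC(=O)NCCO)c2ncccc2c1`: "not determined" (no result reported)
compound 2, `COc1cc(NC(C)CCCNC(=O)NC2CCCC2)c2ncccc2c1`: "not determined" (no result reported)
compound 3, `COc1cc(NC(C)CCCNC(=O)NNC(=O)/C=C/c2cccc(C(F)(F)F)c2)c2ncccc2c1`: 10600 nM

Among the measured compounds shown here, in an ADME assay on L6 cells (Rattus norvegicus) for cytotoxicity, read by resazurin assay, with a stated time of 70 h (a higher number here means a weaker inhibitor, a lower number a stronger inhibitor), compound 3 gives 10600 nM, the only number; compound 1 and compound 2 have no result, so compound 3 stands alone without any neighbour to compare against.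

Compound 4, `COc1cc(NC(C)CCCNC(=O)NNC(=O)Nc2ccc(Cl)cc2)c2ncccc2c1`, differs from compound 3 in one place: (4-chlorophenyl)amino in place of 2-(3-(trifluoromethyl)phenyl)ethenyl on a carbonyl carbon. For the measured compounds named here, no step between measured compounds is available to anchor this change, so the expectation rests on compound 3 alone. Given that compound 3 gives 10600 nM in this assay, compound 4 is expected to sit close to it, with a step from compound 3 to compound 4 of a 1.4-fold higher number from compound 3 to compound 4 (0.15 log units; within the scatter), not clearly beyond the scatter. Compound 4 is estimated at 15000 nM, within 5000 nM to 45000 nM.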

Compound 4, half-maximal inhibitory concentration: 91900 nM
Estimate against measurement, compound 4: 6.1-fold (0.79 log units) below; the whole stated range lies below it.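

In this assay the group on this carbonyl carbon clearly matters: (4-chlorophenyl)amino in place of 2-(3-(trifluoromethyl)phenyl)ethenyl gives an 8.7-fold higher number from compound 3 to compound 4 (0.94 log units; beyond the scatter) and provides the series' first step beyond the scatter. No measured evidence bears on the cause of this step. The change replaces the whole group at once, so the contributions of the chlorine, the trifluoromethyl, the ethenyl and the amino nitrogen cannot be separated. On these data alone, whether a simple amine or a carboxylic acid on this carbonyl carbon would move the value further remains open. The same holds for a 3-(trifluoromethyl)phenylamino group, which would separate the ring substituent from the amino nitrogen.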